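Moving Fluorine and Adding Methyl on the Amide Ring

The compounds below may be only part of what the source reports. "The series", "measured", "known", "first", "only" and "open" are said of these compounds alone.

Compound 1 `O=C(CN1CCC(c2cccc[n+]2[O-])CC1)Nc1cccc(F)c1` is an amide whose nitrogen carries a 3-fluorophenyl ring. Going by the values given here, in a functional assay on HEK293 cells for agonist activity at D(4) dopamine receptor (Homo sapiens), read by FLIPR (on this read-out lower numbers stand for an effect already at smaller amounts and higher numbers for an effect only at larger amounts of compound), compound 1 gives 160 nM, the second highest of the three numbers measured so far. The nearest neighbour is compound 3 `O=C(CN1CCC(c2cccc[n+]2[O-])CC1)Nc1cccc(-c2ccccc2)c1`, which gives 360 nM; the step of a 2.3-fold higher number from compound 1 to compound 3 (0.35 log units; beyond the scatter) is a modest one. The furthest is compound 2 `Cc1cccc(NC(=O)CN2CCC(c3cccc(O)c3)CC2)c1`, which gives 8 nM. Compound 2 differs from compound 1 both in its core and in the ring on the amide nitrogen, so its far lower number cannot be tied to any single change.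

Among the compounds with values here, compound 4 `Cc1cc(F)ccc1NC(=O)CN1CCC(c2cccc[n+]2[O-])CC1` has not yet been measured. 4-fluoro-2-methylphenyl in place of 3-fluorophenyl on an amide-type nitrogen The only measured step that touches this ring is the one from compound 1 to compound 3, which swapped one substituent on the ring and gave a modest rise. Within the data shown here, no measured pair shows the exact change made here, so the direction is uncertain, but a modest step is the most reasonable expectation. Compound 4 is therefore expected to give 250 nM, with a likely range of 80 nM to 800 nM, meaning an expected step of a 1.6-fold higher number from compound 1 to compound 4 (0.19 log units; within the scatter).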

Compound 4, half-maximal effective concentration: 60 nM
Estimate against measurement, compound 4: 4.2-fold (0.62 log units) above, and the stated range ends above it.
By their numbers in this assay, from the lowest: compound 2; then compound 4; then compound 1; then compound 3.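

On the amide-type nitrogen of this core, 4-fluoro-2-methylphenyl in place of 3-fluorophenyl gives a 2.7-fold lower number from compound 1 to compound 4 (0.43 log units; beyond the scatter) in this assay. Going by these compounds alone, the only earlier step at this ring, phenyl in place of fluoro, went the other way with a 2.3-fold higher number from compound 1 to compound 3 (0.35 log units; beyond the scatter), so changes on this ring can move the number in either direction while the rest of the molecule stays the same. The new ring also differs from the old one in two ways at once, with the fluoro group in a different place and a methyl group added, and nothing measured here offers an explanation for the lower number.

The two parts of the change remain to be separated, which would take a ring carrying only the added methyl group and another carrying only the moved fluoro group. From the compounds shown here alone, it also remains open how a methoxy group or an amine in place of the methyl group would behave, and whether the same ring would lower the number on the core of compound 2.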